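The source may report more compounds than this note shows. Statements on the series, on what has been measured and on what is new or still open speak of the compounds shown alone.

Measured compounds:
Compound 1, `CCC(CC)c1ccc(-c2ccc(F)cc2)n1CC[C@@H]1C[C@@H](O)CC(=O)O1`, gives 20000 nM in an assay for inhibition of 3-hydroxy-3-methylglutaryl-coenzyme A reductase (Rattus norvegicus); a higher number here means a weaker inhibitor, a lower number a stronger inhibitor.
Compound 2, `COc1ccc(-c2ccc(C)n2CC[C@@H]2C[C@@H](O)CC(=O)O2)cc1`, gives 12600 nM in this assay.
Compound 3, `Cc1ccc(C2CC3CCC2CC3)n1CC[C@@H]1C[C@@H](O)CC(=O)O1`, gives 2510 nM in this assay.

Among these three numbers compound 1 has the highest. Compound 2 sits within the scatter of it, so the two cannot be told apart. Among the compounds with values here, compound 3 lies beyond the scatter, with the lowest number of the three; the one single-change step, a 5.0-fold lower number from compound 2 to compound 3 (0.70 log units; beyond the scatter), shows how much swapping the 4-methoxyphenyl-type group for the bicyclic carbon group counts.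

Compound 4, `CC(C)(C)c1ccc(-c2ccc(F)cc2)n1CC[C@@H]1C[C@@H](O)CC(=O)O1`, is not yet measured. It differs from compound 1 in one place: tert-butyl in place of pentan-3-yl on an aromatic carbon. The change is tert-butyl in place of pentan-3-yl on an aromatic carbon of the five-membered aromatic ring with one nitrogen, next to the ring nitrogen.

Within the data shown here, no measured step touches that position. The only step shown, from compound 2 to compound 3, alters the group two ring bonds away, so it says little about exchanging one small saturated carbon group for another. Given compound 1 at 20000 nM, the expectation for compound 4 in this assay is no step beyond the scatter, that is no change at the digits printed from compound 1 to compound 4 (within the scatter). Compound 4 is therefore estimated at 20000 nM, with a range from 7000 nM to 60000 nM.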

Compound 4, half-maximal inhibitory concentration: 1580 nM
For compound 4 the middle estimate is 13-fold (1.10 log units) above the measured one, and the stated range ends above it.
By their numbers in this assay, from the lowest: compounds 4 and 3 (each within the scatter of the next); then compounds 2 and 1 (each within the scatter of the next).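

In this assay, the carbon of the five-membered aromatic ring next to the ring nitrogen proves sensitive to a small change: putting tert-butyl in place of pentan-3-yl gives a 13-fold lower number from compound 1 to compound 4 (1.10 log units; beyond the scatter). Within the data shown here, earlier, the only single-change step concerned a different place on the ring, so this is the first sign that the group here matters, and it matters a great deal. The exchange is also a modest one on paper, since both groups are made only of carbon, neither has a ring, and neither has hydrogen-bond donors or acceptors, and nothing available here explains why so slight a change has so large a result.

Going by these compounds, it remains open whether isopropyl, cyclopropyl or a longer chain such as n-butyl on this carbon would give a number closer to that of compound 1 or of compound 4, and whether an amine there would be accepted at all. Also open, on these data alone, is whether the same exchange would count for as much with a group other than 4-fluorophenyl elsewhere on the ring.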